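The source may hold more compounds than are shown below. What is called first, only, known or untested is meant among the compounds shown, and "the series" means these compounds.

Compound 2 `COc1cccc2c1C(=O)C(O)(O)C2=O` is one of two measured compounds in an assay on isolated protein for inhibition of carbonic anhydrase 4 (Homo sapiens), read by stopped-flow, with a stated time of 15 min; on this read-out higher numbers stand for weaker inhibition and lower numbers for stronger inhibition. In this assay compound 2 gives > 100000 nM, which is a limit rather than a number. Compound 1 `CC(C)Oc1cccc2c1C(=O)C(O)(O)C2=O` likewise sits at a limit, giving > 100000 nM in this assay, so the step that the two limits leave unreadable from compound 1 to compound 2 cannot be read, and both values fall at the limit of > 100000 nM in this assay, at which 2 of the 2 values shown sit. Compound 3 `COc1ccc(C(C)C)c2c1C(=O)C(O)(O)C2=O` differs from compound 2 by isopropyl in place of hydrogen on an aromatic carbon. Within the data shown here, no measured step bears on this change, and with compound 2 at a limit, the step that the limit leaves unreadable from compound 2 to compound 3 is expected to leave compound 3 at a limit too. Compound 3 is therefore estimated at 200000 nM, within 30000 nM to 2000000 nM.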

Compound 3, inhibition constant: > 100000 nM
Compound 3 ended at the assay's limit; the forecaster's own chance of this, stated with the estimate: 85%; the middle value does not contradict the limit.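

The step between compound 2 and compound 3 cannot be read, as both sit at a limit: the limit of > 100000 nM in this assay, at which 3 of the 3 values shown sit. The compounds shown leave open how strongly any of them inhibits in this assay and which change to the shared core would give a readable value.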